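Ring swap on the shared core and Alpha-1B maximal response

The source may hold more compounds than are shown below. What is called first, only, known or untested is meant among the compounds shown, and "the series" means these compounds.

Measured so far:
compound 1 `Cn1cccc1-c1ccccc1NCC1=NCCN1` gives 0%
compound 2 `Cc1n[nH]c(-c2ccccc2NCC2=NCCN2)n1` gives 0%
compound 3 `Cn1ccc(-c2ccccc2NCC2=NCCN2)n1` gives 33%

These three compounds share a core and differ only in one aromatic ring attached to it. In a functional assay with Alpha-1B adrenergic receptor (Homo sapiens) as the target, read by calcium flux (on this read-out lower numbers stand for smaller maximal responses and higher numbers for larger maximal responses), compound 3 stands highest of the three; its nearest neighbour is compound 1, and the step of a number 33 percentage points higher from compound 1 to compound 3 (beyond the scatter) is large, as is the step of a number 33 percentage points higher from compound 2 to compound 3 (beyond the scatter). Between compound 1 and compound 2 the step of no change at the digits printed from compound 1 to compound 2 (within the scatter) shows nothing beyond the scatter.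

Compound 4 `c1ccc(-c2nc[nH]n2)c(NCC2=NCCN2)c1` has not yet been measured. It differs from compound 3 in one place: 1H-1,2,4-triazol-3-yl in place of 1-methyl-1H-pyrazol-3-yl on an aromatic carbon. Among the compounds with values here, the step that bears most on this is the one from compound 2 to compound 3, where a 1,2,4-triazolyl ring gave way to the methylated pyrazolyl ring and the maximal response rose by a number 33 percentage points higher from compound 2 to compound 3 (beyond the scatter). Compound 4 returns to a 1,2,4-triazolyl ring carrying a hydrogen-bond donor, so the reverse direction is expected: a drop of roughly a number 25 percentage points lower from compound 3 to compound 4 (beyond the scatter) in this assay. Compound 4 is therefore estimated at 8%, with a range from 0% to 25%.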

Compound 4, largest response reached (reported as maximal response), in percent of the reference or control that the assay uses: 100%
Compound 4: middle estimate off by 92 percentage points, on the low side, outside the stated range (above it).
By their numbers in this assay, from the lowest: compounds 1 and 2 (each within the scatter of the next); then compound 3; then compound 4.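

In this assay, a 1,2,4-triazolyl ring on this aromatic carbon, ortho to a group of 7 heavy atoms, is no bar to a response: exchanging the 3-methyl-1H-1,2,4-triazol-5-yl ring for 1H-1,2,4-triazol-3-yl gives a number 100 percentage points higher from compound 2 to compound 4 (beyond the scatter) in this comparison. So the earlier link between a triazolyl ring and a low response does not hold for every such ring, and the exact ring at this place matters greatly. The same ring also gives a number 67 percentage points higher from compound 3 to compound 4 (beyond the scatter) and a number 100 percentage points higher from compound 1 to compound 4 (beyond the scatter) when it replaces the two rings with a methyl on nitrogen, which puts compound 4 highest of the four.

No measurement shown here explains these steps. From the compounds shown here alone, whether a plain phenyl ring, an amide or a carboxylic acid at this place would keep such a response remains open.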